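Replacing the cyclopentylmethyl ester with a carboxy group

The source may hold more compounds than are shown below. What is called first, only, known or untested is meant among the compounds shown, and "the series" means these compounds.

Three esters of one shared core have been tested in a functional assay on KB3 cells (Homo sapiens) for antiproliferative activity, read by MTT assay, with a stated time of 96 h; on this read-out lower numbers stand for stronger inhibition and higher numbers for weaker inhibition. Compound 1 `C=C(C)[C@H]1CC=C(C)[C@@]2(O)[C@@H]1[C@H](c1ccccc1Br)O[C@@H]2C(=O)OC` gives 5000 nM in this assay. Compound 2 `C=C(C)[C@H]1CC=C(C)[C@@]2(O)[C@@H]1[C@H](c1ccccc1Br)O[C@@H]2C(=O)OCC1CC1` gives 50000 nM. Among the compounds with values here, for compound 3 `C=C(C)[C@H]1CC=C(C)[C@@]2(O)[C@@H]1[C@H](c1ccccc1Br)O[C@@H]2C(=O)OCC1CCCC1` the result is a limit, > 100000 nM, so only an upper bound on its potency is known; it is the one value that sits at the limit of > 100000 nM in this assay, at which 1 of the 3 values shown sits. Across the measured compounds, the esters with larger groups give higher numbers: a 10-fold higher number from compound 1 to compound 2 (1.00 log units; beyond the scatter) and an at least 20-fold higher number from compound 1 to compound 3 (1.30 log units; beyond the scatter), while an at least 2.0-fold higher number from compound 2 to compound 3 (0.30 log units; that floor lies within the scatter) rests on a limit.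

Compound 4 `C=C(C)[C@H]1CC=C(C)[C@@]2(O)[C@@H]1[C@H](c1ccccc1Br)O[C@@H]2C(=O)O` differs from compound 3 by hydrogen in place of cyclopentylmethyl on an oxygen next to a carbonyl group, that is, cyclopentylmethoxycarbonyl becomes carboxy. Within the data shown here, no measured step covers the loss of the ester group altogether; the measured steps only compare one ester group with another. The expected step of a number no higher from compound 3 to compound 4 (the limit leaves the size open) is therefore highly uncertain, and compound 4 is expected to give about 100000 nM in this assay, within a range from 10000 nM to 300000 nM, with a real chance that only a limit is reported.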

Compound 4, half-maximal inhibitory concentration: > 100000 nM
Compound 4: no number, only a limit (the forecaster's own chance of this, stated with the estimate: 55%); the middle value lies on the limit itself.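

In this assay, taking the alkyl group off this oxygen altogether does not improve on the methyl ester, giving an at least 20-fold higher number from compound 1 to compound 4 (1.30 log units; beyond the scatter), so the earlier rise in numbers from the methyl ester to the larger esters does not mean that less on this oxygen is always better. Against the cyclopropylmethyl ester the step is only a floor, an at least 2.0-fold higher number from compound 2 to compound 4 (0.30 log units; that floor lies within the scatter), so the carboxy compound cannot be ranked against that ester, and the step between the two compounds that rest on limits cannot be read. Compound 4 is the second compound whose result is a limit of the assay: the limit of > 100000 nM in this assay, at which 2 of the 4 values shown sit.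

The compounds shown leave open whether an ethyl ester or a primary amide in place of the ester would match or better compound 1. They also leave open how much weaker compound 3 and compound 4 really are.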